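This account rests on a few compounds, and the source may have more. Where it says the series, first, only, none or still open, it means among the compounds named here.

Measured compounds:
compound 1 `Nc1nc(-c2ccccc2)c(C(=O)c2cnc3ccccn23)s1`, 40%
compound 2 `Cc1ccc2ncc(C(=O)c3sc(N)nc3-c3ccccc3)n2c1`, 77%
compound 3 `Cc1ccn2c(C(=O)c3sc(N)nc3C)cnc2c1`, 66%

In a functional assay on the whole organism (strain Sprague-Dawley) for inhibition, with Rattus norvegicus as the target, read by paw edema, with stated times of 1 h and 3 h, at a dose of 50 mg/kg by the oral route (a higher number here means more inhibition at the dose given (going by the name of the read-out), a lower number less inhibition), compound 2 gives the highest of the three numbers; compound 3 comes nearest and compound 1 lies furthest away. Compound 4 `Cc1ccc2ncc(C(=O)c3sc(N)nc3C)n2c1` has not been measured; it differs from compound 2 by methyl in place of phenyl on an aromatic carbon.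

Within the data shown here, no measured step matches this change directly. The single listed step, a number 37 percentage points higher from compound 1 to compound 2 (beyond the scatter), concerns a methyl added on the other part of the molecule, so it says nothing about swapping phenyl for methyl. What remains is a comparison of values: compound 3, which already carries methyl on that ring, gives 66%, while compound 2 with phenyl gives 77%; the two differ in a second place as well, so only the gap itself can be noted.

On this basis a modest fall is expected for compound 4, with a number 12 percentage points lower from compound 2 to compound 4 (beyond the scatter), and a value near that of compound 3. The estimate for compound 4 is 65%, between 45% and 85%.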

Compound 4, a percentage reported as inhibition, in the whole organism at one dose (the size of the read-out at that dose, not a potency): 33%
The estimate for compound 4 lay 32 percentage points above the measured number; measured number outside the range, below it.
By their numbers in this assay, from the lowest: compounds 4 and 1 (each within the scatter of the next); then compound 3; then compound 2.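

On the aromatic carbon next to the ring nitrogen, phenyl carries much of the effect in this pair: in this assay, methyl in its place gives a number 44 percentage points lower from compound 2 to compound 4 (beyond the scatter), a large step. Methyl on this carbon does not always go with a low number, however: compound 4 gives 33%, while compound 3, which has its second methyl at a different place on the other ring system, gives 66%, so the outcome also shifts with where that second methyl sits. Nothing available here accounts for either drop.

The compounds shown leave open how a group of intermediate size, such as ethyl or a longer chain like butyl, would fare on this carbon. They also leave open whether cyclohexyl, a ring that is not aromatic, could stand in for phenyl there.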